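Tert-butoxycarbonyl chain on the shared core: compound 4

The compounds below may be only part of what the source reports. "The series", "measured", "known", "first", "only" and "open" are said of these compounds alone.

- compound 1 `CCN1CCc2c(sc(NC(=O)Nc3ccc(Cl)cc3)c2C(N)=O)C1`: 3120 nM
- compound 2 `NC(=O)c1c(NC(=O)Nc2ccc(Cl)cc2)sc2c1CCN(C1CCOCC1)C2`: 2830 nM
- compound 3 `COCCCN1CCc2c(sc(NC(=O)Nc3ccc(Cl)cc3)c2C(N)=O)C1`: 2400 nM

In a functional assay (strain AB) with Danio rerio as the target, read by microscopy, with a stated time of 1 h (on this read-out higher numbers stand for an effect only at larger amounts of compound and lower numbers for an effect already at smaller amounts), compound 3 gives 2400 nM, within the scatter of the other two: a 1.3-fold lower number from compound 1 to compound 3 (0.11 log units; within the scatter), and a 1.2-fold lower number from compound 2 to compound 3 (0.07 log units; within the scatter). Compound 4 `CC(C)(C)OC(=O)CCCN1CCc2c(sc(NC(=O)Nc3ccc(Cl)cc3)c2C(N)=O)C1` carries tert-butoxycarbonyl in place of methoxy on a saturated chain carbon, three bonds along the chain from an amine nitrogen in a ring. The remaining measured step on that amine nitrogen, a 1.1-fold lower number from compound 1 to compound 2 (0.04 log units; within the scatter), is also within the scatter. Among the measured compounds shown here, all three steps are small, yet no measured compound carries tert-butoxycarbonyl, so the range stays wide. No step beyond the scatter is expected in this assay. The expected step is a 1.0-fold higher number from compound 3 to compound 4 (0.02 log units; within the scatter). For compound 4 the estimated value is 2500 nM, with an expected range of 1100 nM to 5500 nM.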

Compound 4, half-maximal effective concentration: 560 nM
Beside the measured number, compound 4's estimate is 4.5-fold (0.65 log units) above it, and the stated range ends above it.
By their numbers in this assay, from the lowest: compound 4; then compounds 3, 2 and 1 (each within the scatter of the next).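

In this assay, among the compounds shown here, the amine nitrogen of the shared core responds to its substituent for the first time, with the 3-(tert-butoxycarbonyl)propyl chain giving a 4.3-fold lower number from compound 3 to compound 4 (0.63 log units; beyond the scatter) and a 5.1-fold lower number from compound 2 to compound 4 (0.70 log units; beyond the scatter) and a 5.6-fold lower number from compound 1 to compound 4 (0.75 log units; beyond the scatter) while all earlier changes stayed within the scatter. Compound 3 has the same chain length with methoxy at the end, so the step goes with exchanging methoxy for tert-butoxycarbonyl and not with the chain alone. No available evidence accounts for this step. Still open, from the compounds shown here alone, is whether the free carboxylic acid or the methyl ester keeps the lower number. Going by these compounds, a shorter or longer chain ending in tert-butoxycarbonyl is equally open.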